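The source may report more compounds than this note shows. Statements on the series, on what has been measured and on what is new or still open speak of the compounds shown alone.

Measured compounds:
compound 1 `COc1ccc2[nH]cc(/C=C(\C#N)C(=O)c3c[nH]c4ccc(OC)cc34)c2c1` — > 50000 nM
compound 2 `COc1ccc(Cn2cc(/C=C(\C#N)C(=O)c3c[nH]c4cc(OC)ccc34)c3ccccc32)cc1` — > 50000 nM

In a functional assay on PC-3 cells (Homo sapiens) for cytotoxicity, read by WST assay, with a stated time of 24 h (on this read-out higher numbers stand for weaker inhibition and lower numbers for stronger inhibition), compound 1 gives > 50000 nM, which is a limit of the assay and not a number. Compound 2 likewise gives > 50000 nM in this assay, again a limit rather than a number. Going by the values given here, compound 1 therefore stands at the edge of what this assay can report, and so does the one other compound measured here (the limit of > 50000 nM in this assay, at which 2 of the 2 values shown sit). Among the compounds with values here, no step between measured compounds is available, so nothing in these two values says how a change on the shared core moves the read-out.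

Compound 3 `COc1ccc2[nH]cc(/C=C(\C#N)C(=O)c3c[nH]c4ccccc34)c2c1` is not yet measured in this assay. It differs from compound 1 by hydrogen in place of methoxy on an aromatic carbon. Whether the loss of the methoxy group changes inhibition cannot be read from compound 1 and compound 2, since both sit at the limit. The step from compound 1 to compound 3 is expected to be a number no higher from compound 1 to compound 3 (the limit leaves the size open), that is, no movement beyond the scatter. Compound 3 is estimated to give 50000 nM in this assay, within a range from 15000 nM to 100000 nM, most likely again as a limit.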

Compound 3, half-maximal inhibitory concentration: 33200 nM
Beside the measured number, compound 3's estimate is 1.5-fold (0.18 log units) above it; the range from low to high includes it.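

In this assay, going by these compounds alone, hydrogen in place of methoxy on this aromatic carbon gives the first reading that is a number and not a limit, with compound 3 at 33200 nM. The change reads as an at least 1.5-fold lower number from compound 1 to compound 3 (0.17 log units; that floor lies within the scatter), so it is not established that this replacement moves the read-out beyond the scatter, although a larger step remains possible. The true size of the step stays open because compound 1 stands at a limit of the assay and not at a number: the limit of > 50000 nM in this assay, at which 2 of the 3 values shown sit.

Going by these compounds, whether a fluorine atom, a hydroxyl group or an amine on this same carbon would give a different reading from hydrogen remains open. Also open, on these data alone, is what the methoxy group that compound 3 retains contributes to its reading in this assay.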